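Chloro in Place of Fluoro: What to Expect for Compound 4

This account rests on a few compounds, and the source may have more. Where it says the series, first, only, none or still open, it means among the compounds named here.

Compound 1 `O=C(CSc1nc(Nc2ccccc2)c2ccccc2n1)Nc1ccc(F)cc1` and compound 2 `O=C(CSc1nc(Nc2ccccc2)c2ccccc2n1)Nc1ccc(Cl)cc1` share one core and differ in a single place, the change being (chloro in place of fluoro on an aromatic carbon). In a functional assay on PC-3 cells (Homo sapiens) for inhibition, read by MTT assay, with a stated time of 72 h (on this read-out lower numbers stand for stronger inhibition and higher numbers for weaker inhibition), compound 1 gives 9560 nM, and compound 2 gives 12900 nM; the step is a 1.3-fold higher number from compound 1 to compound 2 (0.13 log units; within the scatter). Compound 3 `C=CC(=O)Nc1cccc(NC(=O)CSc2nc(Nc3ccc(F)cc3)c3ccccc3n2)c1` rests on another core, and the difference between the two cores is not broken down here. In this assay compound 3 gives 8240 nM. Compound 4 `C=CC(=O)Nc1cccc(NC(=O)CSc2nc(Nc3ccc(Cl)cc3)c3ccccc3n2)c1` has not yet been measured. From compound 3 to compound 4 the change is chloro in place of fluoro on an aromatic carbon, the same change as from compound 1 to compound 2, made at the same place. Because the earlier step was a 1.3-fold higher number from compound 1 to compound 2 (0.13 log units; within the scatter), a step of like size is expected for compound 4, namely a 1.3-fold higher number from compound 3 to compound 4 (0.11 log units; within the scatter). Compound 4 is therefore estimated at 10500 nM, expected to fall between 5500 nM and 20000 nM.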

Compound 4, half-maximal inhibitory concentration: 10800 nM
For compound 4 the middle estimate is 1.0-fold (0.01 log units) below the measured one, within the range that was stated.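

In this assay, chloro in place of fluoro gives a 1.3-fold higher number from compound 3 to compound 4 (0.12 log units; within the scatter). Set beside the earlier step, the change reads alike on the two cores: the same change on two cores in this assay, a 1.3-fold higher number (0.13 log units; within the scatter) from compound 1 to compound 2 and a 1.3-fold higher number (0.12 log units; within the scatter) from compound 3 to compound 4, 1.0-fold (0.01 log units) apart, within the scatter of two such steps. Among these compounds, neither step stands clear of the scatter, so the match shows only that the swap leaves the numbers indistinguishable on these two cores; it does not show that a change with a larger step would carry over, nor that other cores would behave alike.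

The compounds shown leave open how bromo, a methoxy group or an amine would read in place of fluoro or chloro in this assay. They also leave open whether the same swap holds on any further core.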